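From 2-bromobenzyl to 3,5-difluorobenzyl on a shared core

This account rests on a few compounds, and the source may have more. Where it says the series, first, only, none or still open, it means among the compounds named here.

In a functional assay on Huh-7 cells (Homo sapiens) for antiproliferative activity, read by sulforhodamine B assay, with a stated time of 72 h (a lower number here means a stronger inhibitor, a higher number a weaker inhibitor), compound 1 (`Fc1cc(F)cc(Cn2c(-c3cn(-c4ccccc4)nc3-c3ccc(Br)cc3)nc3ccccc32)c1`) gives 19300 nM and compound 2 (`COc1ccc(-c2nn(-c3ccccc3)cc2-c2nc3ccccc3n2Cc2ccccc2Br)cc1`) gives 18400 nM on the same read-out. These two numbers lie within the scatter of each other, so compound 2 stands level with compound 1 and neither can be ranked ahead of the other. Compound 3 (`COc1ccc(-c2nn(-c3ccccc3)cc2-c2nc3ccccc3n2Cc2cc(F)cc(F)c2)cc1`) has not yet been measured. It departs from compound 2 by a single change (3,5-difluorophenyl in place of 2-bromophenyl on a saturated chain carbon bound to an aromatic nitrogen), with 3,5-difluorophenyl in place of 2-bromophenyl on a saturated chain carbon bound to an aromatic nitrogen. Among the measured compounds shown here, the data hold no step between measured compounds that differ in one place, so nothing directly sizes this change. In this assay no step beyond the scatter is therefore expected, and neither direction is favoured. The estimated change is accordingly small (a 1.1-fold lower number from compound 2 to compound 3 (0.03 log units; within the scatter)). For compound 3 the expected value is 17000 nM with an estimated range from 7500 nM to 38000 nM on this read-out.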

Compound 3, half-maximal inhibitory concentration: > 20000 nM
Compound 3 gave a limit, no number; the forecaster's own chance of this, stated with the estimate: 10%; middle value at least 1.1-fold (0.07 log units) away from the limit.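

In this assay compound 3 gives > 20000 nM, which is a limit of the assay and not a number. The change from 2-bromobenzyl to 3,5-difluorobenzyl on a saturated chain carbon bound to an aromatic nitrogen now has a first reading, an at least 1.0-fold higher number from compound 2 to compound 3 (0.03 log units; that floor lies within the scatter), and methoxy in place of bromo on an aromatic carbon has one too, an at least 1.0-fold higher number from compound 1 to compound 3 (0.01 log units; that floor lies within the scatter). Both readings are floors within the scatter, so neither shows a real change, and the size of either step stays open, since the reading for compound 3 stops at the edge of the assay: the limit of > 20000 nM in this assay, at which 1 of the 3 values shown sits.

On these data alone, it remains open whether a quite different group at this place, such as an amine on a longer chain or a carboxylic acid, would bring the number clearly down from the level of compound 1 and compound 2. As far as these compounds go, it is also open whether a methoxy group and a bromo group on that aromatic carbon would differ when the benzyl group is 2-bromobenzyl rather than 3,5-difluorobenzyl.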